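Lengthening the side chain of compound 2

The source may hold more compounds than are shown below. What is called first, only, known or untested is meant among the compounds shown, and "the series" means these compounds.

Among the compounds with values here, compound 2 (`CCN(CC)CCCn1c(N)c(-c2nc3cc(Cl)ccc3[nH]2)c2nc(C#N)c(C#N)nc21`) stands at 4830 nM in a functional assay on K562 cells (Homo sapiens) for antiproliferative activity, read by MTT assay, with a stated time of 48 h (a higher number here means a weaker inhibitor, a lower number a stronger inhibitor), and holds the higher of the two numbers so far. Compound 1 (`CCN(CC)CCCCn1c(N)c(-c2nc3ccccc3[nH]2)c2nc(C#N)c(C#N)nc21`) gives 1440 nM in this assay and the gap between the two lies beyond the scatter. Compound 3 (`CCN(CC)CCCCn1c(N)c(-c2nc3cc(Cl)ccc3[nH]2)c2nc(C#N)c(C#N)nc21`) is still unmeasured and differs from compound 2 by (diethylamino)methyl in place of diethylamino on a saturated chain carbon, three bonds along the chain from an aromatic nitrogen (the change reads 3-(diethylamino)propyl to 4-(diethylamino)butyl). Within the data shown here, no measured pair shows this change alone, so in this assay only a small move toward a lower number is expected, and the estimated step of a 1.6-fold lower number from compound 2 to compound 3 (0.21 log units; within the scatter) may stay within the scatter. Compound 3 is estimated at 3000 nM with an expected range from 1100 nM to 8000 nM as the working figure.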

Compound 3, half-maximal inhibitory concentration: 1270 nM
Beside the measured number, compound 3's estimate is 2.4-fold (0.37 log units) above it; low and high end bracket the measured number.
By their numbers in this assay, from the lowest: compounds 3 and 1 (each within the scatter of the next); then compound 2.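

In this assay, within the data shown here, 4-(diethylamino)butyl in place of 3-(diethylamino)propyl gives a 3.8-fold lower number from compound 2 to compound 3 (0.58 log units; beyond the scatter), the first reading of this chain change alone. Among these compounds, with the 4-(diethylamino)butyl chain in both compounds, chloro in place of hydrogen on an aromatic carbon gives a 1.1-fold lower number from compound 1 to compound 3 (0.05 log units; within the scatter), a step the scatter cannot separate from no step. Nothing available explains the chain step.

Among the compounds shown here, whether the chain step recurs without the chloro group stays open, as only one matched pair shows it. Also open, from the compounds shown here alone, is how a longer chain, or a piperidine in place of diethylamino, would read.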